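The source may hold more compounds than are shown below. What is called first, only, known or untested is meant among the compounds shown, and "the series" means these compounds.

In a functional assay on A549 cells (Homo sapiens) for antiproliferative activity, read by sulforhodamine B assay, with a stated time of 72 h (on this read-out higher numbers stand for weaker inhibition and lower numbers for stronger inhibition), the measured compounds are these
Compound 1 `CC(C)C[C@H](NC(=O)CSc1cc(NS(=O)(=O)c2ccccc2)c2ccccc2c1O)B(O)O` gives 5940 nM
Compound 2 `CC(C)C[C@H](NC(=O)CSc1cc(NS(=O)(=O)c2cccs2)c2ccccc2c1O)B(O)O` gives 7540 nM
Compound 3 `CC(=O)Nc1ccc(S(=O)(=O)Nc2cc(SCC(=O)N[C@@H](CC(C)C)B(O)O)c(O)c3ccccc23)cc1` gives 6700 nM

Compound 3 at 6700 nM cannot be separated from the other two compounds, since the steps (a 1.1-fold higher number from compound 1 to compound 3 (0.05 log units; within the scatter)) and (a 1.1-fold lower number from compound 2 to compound 3 (0.05 log units; within the scatter)) both lie within the scatter. For the measured compounds named here, compound 4 `CC(=O)Nc1ccc(S(=O)(=O)Nc2cc(SCCC(=O)N[C@@H](CC(C)C)B(O)O)c(O)c3ccccc23)cc1` is still to be measured in this assay and differs from compound 3 by a group of 12 heavy atoms (7 carbon, 1 boron, 1 nitrogen, 3 oxygen; no ring) in place of a group of 11 heavy atoms (6 carbon, 1 boron, 1 nitrogen, 3 oxygen; no ring), on a saturated chain carbon bound to a sulfur as its single change. Going by the values given here, no measured step touches that place. The steps available (a 1.3-fold higher number from compound 1 to compound 2 (0.10 log units; within the scatter)) and (a 1.1-fold higher number from compound 1 to compound 3 (0.05 log units; within the scatter)) and (a 1.1-fold lower number from compound 2 to compound 3 (0.05 log units; within the scatter)) all concern the group on the sulfonyl sulfur, so they show only that this series has stayed flat there. The data therefore give no direction for the new change, and no step beyond the scatter is expected, though with wide uncertainty. The expected size of the change is small (a 1.0-fold lower number from compound 3 to compound 4 (0.01 log units; within the scatter)) on this estimate. For compound 4 the estimated value is 6500 nM with an expected range from 2200 nM to 16000 nM in this assay.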

Compound 4, half-maximal inhibitory concentration: 5920 nM
Beside the measured number, compound 4's estimate is 1.1-fold (0.04 log units) above it; the measured number falls inside the stated range.
By their numbers in this assay, from the lowest: compounds 4, 1, 3 and 2 (each within the scatter of the next).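

In this assay, for the compounds shown here, the step of a 1.1-fold lower number from compound 3 to compound 4 (0.05 log units; within the scatter) gives the only reading at this place, on a saturated chain carbon bound to a sulfur, since the earlier steps concerned only the group on the sulfonyl sulfur. It shows that, with compound 3 as the starting point, the group of 12 heavy atoms in place of the group of 11 heavy atoms cannot be told apart from no change on this read-out, so the flatness seen so far is no longer confined to that one site. No available evidence bears on this result.

On these data alone, whether a longer chain, or an amine or a carboxylic acid on this chain, would also leave the number within the scatter remains open. As far as these compounds go, it is also open whether the same change behaves alike with phenyl or thiophen-2-yl on the sulfonyl sulfur.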